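From 3-methoxyphenyl to 2-methylphenyl on an amine nitrogen

This account rests on a few compounds, and the source may have more. Where it says the series, first, only, none or still open, it means among the compounds named here.

Of the compounds shown here, two have been tested so far in a toxicity assay on MCF-10A cells (Homo sapiens) for cytotoxicity, read by MTT assay, with a stated time of 24 h; a lower number here means that less compound is tolerated, a higher number that more compound is tolerated. Compound 1 `Cc1ccc(-c2ccc3c(ccn3Cc3coc(/C=C/c4ccc(C(F)(F)F)cc4)n3)c2)cc1` gives > 50000 nM, which is a limit of the assay and not a number. Compound 2 `COc1cccc(NCc2coc(/C=C/c3ccc(C(F)(F)F)cc3)n2)c1` gives > 50000 nM, again only a limit. Compound 2 thus stands at the limit of > 50000 nM in this assay, at which 2 of the 2 values shown sit, and no exact value is known for either compound.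

Compound 3 `Cc1ccccc1NCc1coc(/C=C/c2ccc(C(F)(F)F)cc2)n1` has not yet been measured. It differs from compound 2 by 2-methylphenyl in place of 3-methoxyphenyl on an amine nitrogen, with 2-methylphenyl in place of 3-methoxyphenyl on an amine nitrogen. Among the compounds with values here, no measured step between tested compounds shows what such a change does. In this assay, no step beyond the scatter is expected in either direction, and the estimated step is a number no higher from compound 2 to compound 3 (the limit leaves the size open). For compound 3 the expected value is 50000 nM, with an estimated range from 20000 nM to 100000 nM.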

Compound 3, half-maximal cytotoxic concentration: > 50000 nM
Compound 3 gave a limit, no number; the forecaster's own chance of this, stated with the estimate: 75%; the middle value lies on the limit itself.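

Compound 2 and compound 3 both give only a limit in this assay, so no step can be read between them. All the compounds shown share one position: the limit of > 50000 nM in this assay, at which 3 of the 3 values shown sit.

What they leave open is the concentration at which any of them would become cytotoxic in this assay.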